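The compounds below may be only part of what the source reports. "The series", "measured", "known", "first", "only" and "open" are said of these compounds alone.

Compound 1, with the structure `COc1cc(/C=C/C(=O)/C=C(O)/C=C/c2ccc(OC(=O)[C@@H](CCSC)NC(=O)OCc3ccccc3)c(OC)c2)ccc1OC(=O)[C@@H](CCSC)NC(=O)OCc1ccccc1`, carries the same amino-acid-derived ester on each of the two phenol positions of the shared core, each capped by a benzyloxycarbonyl group. In a functional assay on the whole organism (strain Wistar) for inhibition, with Rattus norvegicus as the target, read by paw edema, with stated times of 1 h and 4 h, at a dose of 10 mg/kg by the intraperitoneal route (on this read-out higher numbers stand for more inhibition at the one dose given (going by the name of the read-out) and lower numbers for less inhibition), compound 1 gives 108%. This is the highest of the three numbers measured, and the gaps to the other two are beyond the usual scatter. Compound 3, with the structure `COc1cc(/C=C/C(=O)/C=C(O)/C=C/c2ccc(OC(=O)C(C)NC(=O)OC(C)(C)C)c(OC)c2)ccc1OC(=O)C(C)NC(=O)OC(C)(C)C`, gives 46% in this assay, and compound 2, with the structure `COc1cc(/C=C/C(=O)/C=C(O)/C=C/c2ccc(OC(=O)CNC(=O)OCc3ccccc3)c(OC)c2)ccc1OC(=O)CNC(=O)OCc1ccccc1`, gives 39%. Compound 4, with the structure `COc1cc(/C=C/C(=O)/C=C(O)/C=C/c2ccc(OC(=O)[C@H](CCSC)NC(=O)OCc3ccccc3)c(OC)c2)ccc1OC(=O)[C@H](CCSC)NC(=O)OCc1ccccc1`, has not yet been measured. It differs from compound 1 in this way: the two compounds have the same atoms and bonds and differ only in configuration as drawn: 2 of 5 stereo elements differ; a stereocentre at a saturated chain carbon is drawn R in compound 1 and S in compound 4; a stereocentre at a saturated chain carbon is drawn R in compound 1 and S in compound 4. Among the compounds with values here, no pair among the measured compounds differs only in configuration, so the size of such a step in this assay is not known from these data. Given that only the drawn configuration changes, a modest fall is expected, so that from compound 1 to compound 4 the step is estimated at a number 23 percentage points lower from compound 1 to compound 4 (beyond the scatter). Compound 4 is therefore expected to give about 85% in this assay, within a range from 55% to 110%.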

Compound 4, a percentage reported as inhibition, in the whole organism at one dose (the size of the read-out at that dose, not a potency): 101%
The estimate for compound 4 lay 16 percentage points below the measured number; the measured number falls inside the stated range.
By their numbers in this assay, from the lowest: compounds 2 and 3 (each within the scatter of the next); then compounds 4 and 1 (each within the scatter of the next).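

Within the data shown here, this pair is the first to isolate a change in configuration, and it can be read directly for one reason: the fact that compounds 1 and 4 differ only in the configuration as drawn. In this assay the result is a number 7 percentage points lower from compound 1 to compound 4 (within the scatter), so drawing both stereocentres of the amino-acid-derived esters as S rather than R produces no change that can be told from the scatter. For this ester and its benzyloxycarbonyl cap, the high reading at this one dose therefore does not depend on which of these two drawn configurations is present.

The compounds shown leave open whether a compound with one R and one S stereocentre would read the same, and whether configuration would matter at another dose. They also leave open what a free amine in place of the benzyloxycarbonyl cap would do in either configuration.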